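This account rests on a few compounds, and the source may have more. Where it says the series, first, only, none or still open, it means among the compounds named here.

Compound 1 `O=C(Nc1ccc(Cl)cc1)c1cc([N+](=O)[O-])ccc1Cl` in an ADME assay on HepG2 cells (Homo sapiens) for inhibition, with a stated time of 72 h (a lower number here means that less compound is needed, a higher number that more compound is needed for the effect), gives > 25000 nM, a limit of the assay.
Compound 2 `C=CC(=O)Nc1cccc(-c2nc3ccccc3s2)c1` in this assay gives > 25000 nM, also a limit.
Compound 3 `O=C(O)/C=C/C(=O)Nc1cccc(-c2nc3ccccc3s2)c1` in this assay gives > 25000 nM, again a limit.

Compound 3 thus stands at the limit, where all three measured values sit (the limit of > 25000 nM in this assay, at which 3 of the 3 values shown sit). Within the data shown here, the one measured step, a step that the two limits leave unreadable from compound 2 to compound 3, therefore has no readable size. Compound 4 `CC(Cl)C(=O)Nc1cccc(-c2nc3ccccc3s2)c1` differs from compound 3 by 1-chloroethyl in place of 2-carboxyethenyl on a carbonyl carbon. No measured step bears readably on this change, so its direction in this assay cannot be read from the data; the shared core alone has shown no measurable effect. Compound 4 is expected to remain weak, with an estimated 15000 nM between 3000 nM and 25000 nM, meaning an expected step of an at least 1.6-fold lower number from compound 3 to compound 4 (0.22 log units; that floor lies within the scatter).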

Compound 4, half-maximal effective concentration: > 25000 nM
Compound 4: no number, only a limit; the forecaster's own chance of this, stated with the estimate: 55%; middle value at least 1.6-fold (0.22 log units) away from the limit.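

Compound 4, like compound 2 and compound 3, sits at a limit, so no step among these compounds can be read: the limit of > 25000 nM in this assay, at which 4 of the 4 values shown sit.

What the compounds shown leave open is whether changing the group on the carbonyl carbon shifts the concentration needed in this assay at all.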